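Solubility of a fused triazolopyrimidine series: the N-methyl benzamide

The source may report more compounds than this note shows. Statements on the series, on what has been measured and on what is new or still open speak of the compounds shown alone.

Compound 1 `O=C(Nc1ccccc1)c1cnc(NCc2c(F)ccc3c2CCO3)n2cnnc12`: < 1000 nM
Compound 2 `Fc1ccc2c(c1CNc1ncc(Oc3ccccc3)c3nncn13)CCO2`: 8000 nM
Compound 3 `C[C@@H]1CC(=O)N(c2cnc(NCc3c(F)ccc4c3CCO4)n3cnnc23)C1`: 130000 nM

Of the compounds shown here, three sharing one core have been measured in a physicochemical assay for solubility, read by LC-MS, in phosphate buffer, with a stated time of 24 h, at pH 7.4; a lower number here means a less soluble compound, a higher number a more soluble compound. Compound 1 sits at a limit of the assay, (the limit of < 1000 nM in this assay, at which 1 of the 3 values shown sits), rather than at a number. Compound 2 reaches 8000 nM. Compound 3, with its 4-methyl-2-oxopyrrolidin-1-yl group, gives 130000 nM and stands highest of the two numbers, the nearest being compound 2 at a 16-fold higher number from compound 2 to compound 3 (1.21 log units; beyond the scatter). The step from the phenylcarbamoyl of compound 1 is larger still: an at least 130-fold higher number from compound 1 to compound 3 (2.11 log units; beyond the scatter).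

Compound 4 `CN(C(=O)c1ccccc1)c1cnc(NCc2c(F)ccc3c2CCO3)n2cnnc12` has not been measured in this assay. It differs from compound 3 at one place: benzoyl(methyl)amino in place of 4-methyl-2-oxopyrrolidin-1-yl on an aromatic carbon. The new benzoyl(methyl)amino group is an aromatic amide, closer in make-up to the phenylcarbamoyl of compound 1 than to the lactam of compound 3, so the steps of an at least 130-fold higher number from compound 1 to compound 3 (2.11 log units; beyond the scatter) and a 16-fold higher number from compound 2 to compound 3 (1.21 log units; beyond the scatter) bear on it, both large and both in favour of the lactam. Compound 4 is therefore expected to fall well below compound 3 in this assay, a step estimated at a 26-fold lower number from compound 3 to compound 4 (1.41 log units; beyond the scatter). The estimate for compound 4 is 5000 nM, in a range from 1000 nM to 40000 nM.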

Compound 4, solubility: 280000 nM
The estimate for compound 4 lay 56-fold (1.75 log units) below the measured number, and the stated range ends below it.
By their numbers in this assay, from the lowest: compound 2; then compound 3; then compound 4. At a limit, below all of these: compound 1.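

In this assay, a benzoyl(methyl)amino group on this aromatic carbon does not fall short of the lactam: a 2.2-fold higher number from compound 3 to compound 4 (0.33 log units; beyond the scatter), so the 4-methyl-2-oxopyrrolidin-1-yl group is no longer the top of the series, and a six-membered aromatic ring of carbon only in the entering group does not hold the number down here. Groups that all carry such a ring now lie far apart at the same place, with a 35-fold higher number from compound 2 to compound 4 (1.54 log units; beyond the scatter) on replacing phenoxy and an at least 280-fold higher number from compound 1 to compound 4 (2.44 log units; beyond the scatter) on replacing phenylcarbamoyl, so the presence of that ring does not by itself set the number. The value of compound 1 is a limit of the assay and not a number: the limit of < 1000 nM in this assay, at which 1 of the 4 values shown sits.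

On these data alone, what the methyl on the amide nitrogen of compound 4 contributes stays open, as does the place that an amine, a carboxylic acid or a pyridine ring in the benzoyl part would take on the same aromatic carbon. The compounds shown also give no cause for the order among these groups, only the order itself.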